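Shortening the bromoalkoxy chain: from compound 1 to compound 4

A few compounds are considered here, and "the series" means these few. Any claim that something is new, unique, unknown or untested is made for them only; others in the source may bear on it.

Values measured in a functional assay on PC-3 cells (Homo sapiens) for inhibition, read by MTT assay, with a stated time of 48 h (a lower number here means a stronger inhibitor, a higher number a weaker inhibitor), so far:
compound 1 `COc1ccc(-c2coc3cc(OCCCBr)ccc3c2=O)cc1` gives 62600 nM
compound 2 `COc1ccc(-c2coc3cc(OCCCSC(=S)N4CCN(C(=O)OC(C)(C)C)CC4)ccc3c2=O)cc1` gives 1970 nM
compound 3 `COc1ccc(-c2coc3cc(OCCSC(=S)N4CCN(C(=O)OC(C)(C)C)CC4)ccc3c2=O)cc1` gives 3640 nM

Compound 1, at 62600 nM, carries the highest number of the three and is the weakest inhibitor measured here, with both gaps beyond the scatter. Nearest to it is compound 3 at 3640 nM, and furthest from it is compound 2 at 1970 nM, so both of these sit well below it.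

The next compound is compound 4 `COc1ccc(-c2coc3cc(OCCBr)ccc3c2=O)cc1`, still unmeasured in this assay. Against compound 1 the change is bromo in place of bromomethyl on a saturated chain carbon, two bonds along the chain from an oxygen on an aromatic ring, which means bromo in place of bromomethyl on a saturated chain carbon, two bonds along the chain from an oxygen on an aromatic ring. Read one bond further out, this is 3-bromopropoxy to 2-bromoethoxy.

Going by the values given here, no measured step isolates this change. Among the compounds with values here, the only guide is that compound 2 at 1970 nM and compound 3 at 3640 nM lie within the scatter of each other. A small change is therefore expected, with no clear direction. The expected step is a 1.1-fold lower number from compound 1 to compound 4 (0.06 log units; within the scatter), which would stay within the scatter. For compound 4 the estimated value is 55000 nM, with an expected range from 22000 nM to 120000 nM as the outcome.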

Compound 4, half-maximal inhibitory concentration: 41900 nM
Beside the measured number, compound 4's estimate is 1.3-fold (0.12 log units) above it, and the stated range covers the measured number.
By their numbers in this assay, from the lowest: compounds 2 and 3 (each within the scatter of the next); then compounds 4 and 1 (each within the scatter of the next).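

Shortening 3-bromopropoxy to 2-bromoethoxy, on a saturated chain carbon two bonds along the chain from an oxygen on an aromatic ring, gives a 1.5-fold lower number from compound 1 to compound 4 (0.17 log units; within the scatter) in this assay. Going by these compounds alone, this is the first step that isolates chain length with bromo as the chain-end group, and it shows that losing this one carbon does not separate the two bromo compounds, so no order can be given between them. The chain-end group still marks a large difference at the shorter chain length, with compound 3 at 3640 nM and compound 4 at 41900 nM, but nothing available explains the size of either difference.

Still open, on these data alone, is whether a longer chain, such as bromobutoxy, would stay within the scatter of these two bromo compounds or move the number beyond it. Also open, as far as these compounds go, is whether a simple amine, a hydroxyl or a carboxylic acid in place of bromo at the chain end would give numbers near those of the bromo compounds or nearer that of compound 3.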